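Trifluoromethyl in Place of Bromo at the Aromatic Carbon

The compounds below may be only part of what the source reports. "The series", "measured", "known", "first", "only" and "open" are said of these compounds alone.

In an ADME assay on isolated protein for inhibition of Amine oxidase [flavin-containing] B (Homo sapiens) (a lower number here means a stronger inhibitor, a higher number a weaker inhibitor), compound 2 `C#CCNC1CCc2c(SCc3cccc(Cl)c3)cccc21` gives 1090 nM. Compound 1 `C#CCNC1CCc2c(SCc3cccc(C)c3)cccc21` sits at a limit of the assay, > 100000 nM. Compound 3 `C#CCNC1CCc2c(SCc3cccc(Br)c3)cccc21` likewise sits at a limit, > 100000 nM, so only a bound is known for where it stands, and two of the three values share (the limit of > 100000 nM in this assay, at which 2 of the 3 values shown sit). The measured steps bearing on the change are an at least 91-fold lower number from compound 1 to compound 2 (1.96 log units; beyond the scatter) and an at least 91-fold higher number from compound 2 to compound 3 (1.96 log units; beyond the scatter), both large, whereas a step that the two limits leave unreadable from compound 1 to compound 3. Compound 4 `C#CCNC1CCc2c(SCc3cccc(C(F)(F)F)c3)cccc21` differs from compound 3 by trifluoromethyl in place of bromo on an aromatic carbon. For the measured compounds named here, no measured compound carries a trifluoromethyl, and compound 3 itself is only a limit, so no direction can be read from it. Compound 4 is expected near 50000 nM, within 2000 nM to 100000 nM, with a real chance of another limit. That estimate is expected to correspond to an at least 2.0-fold lower number from compound 3 to compound 4 (0.30 log units; that floor lies within the scatter).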

Compound 4, half-maximal inhibitory concentration: 7710 nM
Compound 4: the middle estimate sits 6.5-fold (0.81 log units) above what was measured; the measured number falls inside the stated range.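

In this assay, trifluoromethyl is the second group at this place, after chloro, to give a measured number rather than a limit, with an at least 12-fold lower number from compound 3 to compound 4 (1.11 log units; beyond the scatter) and an at least 12-fold lower number from compound 1 to compound 4 (1.11 log units; beyond the scatter). Chloro still leads among the four groups, with a 7.1-fold higher number from compound 2 to compound 4 (0.85 log units; beyond the scatter). Trifluoromethyl enters with more heavy atoms than bromo yet gives the lower number, so heavy-atom count alone does not order this position.

From the compounds shown here alone, how a methoxy, a nitrile or an amine would behave at this place stays open. The step between compound 1 and compound 3 cannot be read, as both values are limits: the limit of > 100000 nM in this assay, at which 2 of the 4 values shown sit.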